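This account rests on a few compounds, and the source may have more. Where it says the series, first, only, none or still open, it means among the compounds named here.

In an ADME assay on RPTEC cells (Homo sapiens) for cytotoxicity, read by resazurin assay, with a stated time of 4 days (a lower number here means that less compound is tolerated, a higher number that more compound is tolerated), compound 1 `Cc1nc2ccccc2n1-c1ccc(C(=O)NC2CC2)s1` gives > 62000 nM, which is a limit. Compound 2 `O=C(NC1CC1)c1ccc(-n2c(C(F)(F)F)nc3ccccc32)s1` gives > 62000 nM, also a limit, so its standing is known only as the limit of > 62000 nM in this assay, at which 2 of the 2 values shown sit. Compound 3 `CN(C)c1nc2ccccc2n1-c1ccc(C(=O)NC2CC2)s1` differs from compound 2 by dimethylamino in place of trifluoromethyl on an aromatic carbon, on an aromatic carbon between two ring nitrogen atoms. Among the compounds with values here, the one measured step bearing on this change is a step that the two limits leave unreadable from compound 1 to compound 2, which gives no size to carry over. With nothing measured below the limit, no change beyond the scatter is expected in this assay. The estimated change is a number no higher from compound 2 to compound 3 (the limit leaves the size open). For compound 3 the expected value is 62000 nM, with an estimated range of 25000 nM to 120000 nM.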

Compound 3, concentration lethal to 50% of the cells: > 62000 nM
Compound 3: a limit, no number (the forecaster's own chance of this, stated with the estimate: 75%); the middle value lies on the limit itself.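

Compound 3 gives > 62000 nM as a limit, so no step among compound 1, compound 2 and compound 3 can be read: the limit of > 62000 nM in this assay, at which 3 of the 3 values shown sit.

In this assay the compounds shown leave open whether any group at this place gives a measurable value.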